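The source may hold more compounds than are shown below. What is called first, only, known or untested is meant among the compounds shown, and "the series" means these compounds.

Of the compounds shown here, three built on one shared core have been measured for growth inhibition, and a fourth waits for its number. Compound 1 `CNC(=O)c1cc(Oc2ccc3nc(NC(=O)Nc4ccc(Cl)cc4Cl)sc3c2)ccn1` carries a (2,4-dichlorophenyl)amino group on a carbonyl carbon. In a functional assay on SK-BR-3 cells (Homo sapiens) for inhibition, read by MTT assay, with a stated time of 2 days, tested at 100 uM (a higher number here means more inhibition of growth at the concentration tested, a lower number less inhibition of growth), compound 1 gives 91.7%, the highest of the three numbers, but the other two lie close: a number 2.3 percentage points lower from compound 1 to compound 3 (within the scatter) and a number 8.7 percentage points lower from compound 1 to compound 2 (within the scatter), both within the scatter. Compound 2 `CNC(=O)c1cc(Oc2ccc3nc(NC(=O)c4ccc(Cl)cc4)sc3c2)ccn1` gives 83% in this assay, and compound 3 `CNC(=O)c1cc(Oc2ccc3nc(NC(=O)c4cccc(F)n4)sc3c2)ccn1` gives 89.4%; between them stands a number 6.4 percentage points higher from compound 2 to compound 3 (within the scatter), again within the scatter.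

Compound 4 `CNC(=O)c1cc(Oc2ccc3nc(NC(=O)c4cc(Cl)cc(Cl)c4)sc3c2)ccn1` differs from compound 1 in one place: 3,5-dichlorophenyl in place of (2,4-dichlorophenyl)amino on a carbonyl carbon. The two measured steps that bear on this are the ones from compound 1 to compound 2 and from compound 1 to compound 3, each of which also removed the (2,4-dichlorophenyl)amino group from the carbonyl carbon and put a six-membered aromatic ring there instead; neither moved the number beyond the scatter. On that basis no step beyond the scatter is expected in this assay for compound 4 either. Compound 4 is therefore estimated at 87%, with a range from 76% to 95%, which would mean a number 4.7 percentage points lower from compound 1 to compound 4 (within the scatter).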

Compound 4, percent growth inhibition at one concentration: 84.3%
Estimate against measurement, compound 4: 2.7 percentage points above; the range from low to high includes it.
By their numbers in this assay, from the lowest: compounds 2, 4, 3 and 1 (each within the scatter of the next).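

In this assay, the swap of (2,4-dichlorophenyl)amino, which carries a hydrogen-bond donor, for 3,5-dichlorophenyl, which carries none, gives a number 7.4 percentage points lower from compound 1 to compound 4 (within the scatter) and so shows that this donor can go from the carbonyl carbon without a step beyond the scatter, even when the incoming carbon-only ring holds two chlorines, as that of the group leaving does. The choice among the ring groups directly on the carbonyl carbon also leaves the reading unresolved: there is a number 1.3 percentage points higher from compound 2 to compound 4 (within the scatter) and there is a number 5.1 percentage points lower from compound 3 to compound 4 (within the scatter) as well, so 3,5-dichlorophenyl cannot be told apart from either 4-chlorophenyl or 6-fluoropyridin-2-yl at this single concentration. Nothing available explains why these numbers lie so close together.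

Every group shown at this position contains a six-membered aromatic ring, so it stays open whether a morpholine ring, a simple amine, a carboxylic acid or a longer alkyl chain on the carbonyl carbon would keep the number in this range or move it beyond the scatter. On these data alone, it also stays open whether these four compounds would separate at lower concentrations, where a full dose-response curve could rank them.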